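Swapping acetyl for methylsulfonyl on a piperazine nitrogen

A few compounds are considered here, and "the series" means these few. Any claim that something is new, unique, unknown or untested is made for them only; others in the source may bear on it.

Compound 1 `CC(=O)N1CCN(CCN2CCC(CNC(=O)c3cccc4[nH]c(C(C)C)nc34)CC2)CC1`: 76%
Compound 2 `CS(=O)(=O)N1CCN(CC(O)CN2CCC(CNC(=O)c3cccc4[nH]c(C5CC5)nc34)CC2)CC1`: 64%

In a functional assay for agonist activity at 5-hydroxytryptamine receptor 4 (Homo sapiens), read by cAMP accumulation (a lower number here means a smaller maximal response, a higher number a larger maximal response), compound 1 gives the higher of the two numbers, and the gap to compound 2 lies beyond the usual scatter. Compound 3 `CC(C)c1nc2c(C(=O)NCC3CCN(CCN4CCN(S(C)(=O)=O)CC4)CC3)cccc2[nH]1` differs from compound 1 by one change: methylsulfonyl in place of acetyl on an amine nitrogen in a ring. Compound 2 also carries the methylsulfonyl group, but it differs from compound 1 in other places as well, so its value alone cannot show what this single change does. The step from compound 1 to compound 3 is expected to be small and downward, near the edge of the scatter: a number 8 percentage points lower from compound 1 to compound 3 (within the scatter). Compound 3 is therefore estimated at 68%, with a range from 55% to 82%.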

Compound 3, intrinsic activity: the largest response reached, in percent of the reference agonist's: 64%
Compound 3: the middle estimate sits 4 percentage points above what was measured; measured number inside the range.
By their numbers in this assay, from the lowest: compounds 2 and 3 (each within the scatter of the next); then compound 1.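

In this assay the methylsulfonyl group in place of acetyl on the amine nitrogen in the ring gives a number 12 percentage points lower from compound 1 to compound 3 (beyond the scatter) with nothing else altered. This position therefore affects the maximal response, and a modest loss can be assigned to this change alone, which compound 2 could not show given its other differences. Nothing here explains why the response drops.

Going by these compounds, whether a plain methyl or a carboxamide on this nitrogen would keep the larger response remains open. So does whether this change gives a similar step on other versions of the molecule.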